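Same Side-Chain Swap Tried on the Benzothiazole Core

The source may hold more compounds than are shown below. What is called first, only, known or untested is meant among the compounds shown, and "the series" means these compounds.

Compound 1 `c1ccc(-c2nnc(SCCCN3CCN(c4nc5ccccc5o4)CC3)o2)cc1` and compound 3 `c1ccc(-c2nnc(SCCCN3CCN(c4nc5ccccc5s4)CC3)o2)cc1` share most of their structure; the two cores differ by 1,3-benzothiazol-2-yl in place of 1,3-benzoxazol-2-yl on an amine nitrogen in a ring. In a functional assay on A549 cells (Homo sapiens) for inhibition, read by MTT assay, with a stated time of 72 h (a higher number here means a weaker inhibitor, a lower number a stronger inhibitor), compound 1 gives 108000 nM and compound 3 gives 257000 nM, a step of a 2.4-fold higher number from compound 1 to compound 3 (0.38 log units; beyond the scatter). Compound 2 `O=C(NCc1nnc(SCCCN2CCN(c3nc4ccccc4o3)CC2)o1)c1ccccc1` carries the change benzamidomethyl in place of phenyl on an aromatic carbon and in this assay compound 2 gives 102000 nM, so the step of a 1.1-fold lower number from compound 1 to compound 2 (0.02 log units; within the scatter) barely moved the number. Compound 4 `O=C(NCc1nnc(SCCCN2CCN(c3nc4ccccc4s3)CC2)o1)c1ccccc1`, not yet measured, carries the same change on the core of compound 3, described as benzamidomethyl in place of phenyl on an aromatic carbon; the words describing the place are identical for both pairs. Because the step of a 1.1-fold lower number from compound 1 to compound 2 (0.02 log units; within the scatter) stayed within the scatter, the expected step for compound 4 is a 1.1-fold lower number from compound 3 to compound 4 (0.03 log units; within the scatter). The estimate for compound 4 in this assay is 240000 nM, expected to fall between 120000 nM and 480000 nM.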

Compound 4, half-maximal inhibitory concentration: 88700 nM
For compound 4 the middle estimate is 2.7-fold (0.43 log units) above the measured one; measured number outside the range, below it.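

In this assay, putting benzamidomethyl in place of phenyl on the core of compound 3 gives a 2.9-fold lower number from compound 3 to compound 4 (0.46 log units; beyond the scatter), while the same change on the core of compound 1 stayed within the scatter, so this change does not carry over unaltered from one core to the other: the same change on two cores in this assay, a 1.1-fold lower number (0.02 log units; within the scatter) from compound 1 to compound 2 and a 2.9-fold lower number (0.46 log units; beyond the scatter) from compound 3 to compound 4, 2.7-fold (0.44 log units) apart, beyond the scatter of two such steps. Seen from the other direction, putting 1,3-benzothiazol-2-yl in place of 1,3-benzoxazol-2-yl gives a 1.1-fold lower number from compound 2 to compound 4 (0.06 log units; within the scatter), which also fails to match the earlier step for that change: the same change on two cores in this assay, a 2.4-fold higher number (0.38 log units; beyond the scatter) from compound 1 to compound 3 and a 1.1-fold lower number (0.06 log units; within the scatter) from compound 2 to compound 4, 2.7-fold (0.44 log units) apart, beyond the scatter of two such steps. The two changes therefore do not simply add up across these four compounds, but the numbers do not show why.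

On these data alone, it remains open whether the same mismatch would appear with an amine or a carboxylic acid in place of benzamidomethyl. As far as these compounds go, a longer chain in the linker joining the two halves of the molecule is equally open.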